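A benzylthio enone series: indole replaces chlorophenyl

This account rests on a few compounds, and the source may have more. Where it says the series, first, only, none or still open, it means among the compounds named here.

Three compounds of this series have numbers in a functional assay on DU-145 cells (Homo sapiens) for inhibition, read by trypan blue exclusion, with a stated time of 96 h; on this read-out lower numbers stand for stronger inhibition of growth and higher numbers for weaker inhibition of growth. Compound 1 `CN(C)c1ccc(/C=C(/SCc2ccc(Cl)cc2Cl)C(=O)c2ccc(Cl)cc2)cc1` gives 50000 nM in this assay. Compound 2 `Cc1ccc(S/C(=C/c2ccc(Cl)cc2)C(=O)c2ccc(Cl)cc2)cc1` gives 10000 nM in this assay, and compound 3 `O=C(/C(=C\c1ccc(Cl)cc1)SCc1ccc(F)cc1)c1ccc(Cl)cc1` gives 10000 nM in this assay. Among the measured compounds shown here, the single one-place step, no change at the digits printed from compound 2 to compound 3 (within the scatter), concerns the group on the sulfur only. Compound 3 thus stands level with compound 2, the two together at the lowest numbers of the three, while compound 1, which differs from compound 3 in two places, sits at a higher number.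

Compound 4 `O=C(/C(=C\c1c[nH]c2ccc(Br)cc12)SCc1ccc(F)cc1)c1ccc(Cl)cc1` has not been measured. Its change from compound 3 is 5-bromo-1H-indol-3-yl in place of 4-chlorophenyl on a double-bonded chain carbon bound to a double-bonded chain carbon. For the measured compounds named here, no measured step touches the group on the double-bonded chain carbon, and the step from compound 2 to compound 3 at the sulfur, within the scatter, offers no guide for this position. The estimate for compound 4 is therefore wide and rests on compound 3 alone: a value near 6000 nM, between 1000 nM and 30000 nM, is expected, which would be a step of a 1.7-fold lower number from compound 3 to compound 4 (0.22 log units; within the scatter).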

Compound 4, concentration for 50% growth inhibition: 50000 nM
Beside the measured number, compound 4's estimate is 8.3-fold (0.92 log units) below it; the whole stated range lies below it.
By their numbers in this assay, from the lowest: compounds 2 and 3 (each within the scatter of the next); then compounds 1 and 4 (each within the scatter of the next).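

In this assay the group on the double-bonded chain carbon bound to a double-bonded chain carbon proves able to move the number: 5-bromo-1H-indol-3-yl in place of 4-chlorophenyl gives a 5.0-fold higher number from compound 3 to compound 4 (0.70 log units; beyond the scatter) on a change that enters a second aromatic ring and a hydrogen-bond donor. Among the compounds shown here, the only earlier one-place step, at the sulfur, stayed within the scatter, so this is the first position where a single change is seen to weaken inhibition of growth. Nothing at hand accounts for this step.

From the compounds shown here alone, what an unsubstituted 1H-indol-3-yl or a 4-bromophenyl would give at this place remains open, so the step cannot be divided between the bromine and the indole. Also open, going by these compounds, is how an amine or a carboxylic acid would fare on this carbon.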